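Pyridin-2-yl for Phenyl on a Triazole-Bearing Core

The source may hold more compounds than are shown below. What is called first, only, known or untested is meant among the compounds shown, and "the series" means these compounds.

Compound 1, `C=C1C[C@]23C[C@@]1(O)CC[C@H]2c1ccc(OS(=O)(=O)c2ccc(C)cc2)c(C)c1[C@@H]3Cn1cc(-c2ccc(OC)cc2)nn1`: in a functional assay on HL-60 cells (Homo sapiens) for cytotoxicity, read by MTT assay, with a stated time of 4 days (a higher number here means a weaker inhibitor, a lower number a stronger inhibitor), compound 1 gives > 20000 nM, a limit of the assay rather than a number.
Compound 2, `C=C1C[C@]23C[C@@]1(O)CC[C@H]2c1ccc(OS(=O)(=O)c2ccc(C)cc2)c(C)c1[C@@H]3Cn1cc(-c2ccc(C)cc2)nn1`: in this assay compound 2 gives > 20000 nM, again a limit of the assay, not a number.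
Compound 3, `C=C1C[C@]23C[C@@]1(O)CC[C@@H]2c1cccc(C)c1[C@@H]3Cn1cc(-c2ccccc2)nn1`: in this assay compound 3 gives > 20000 nM, also a limit of the assay and not a number.

For the measured compounds named here, the only pair that differs in one place is compound 1 and compound 2; their step that the two limits leave unreadable from compound 1 to compound 2 cannot be read in size because of the limit of > 20000 nM in this assay, at which 3 of the 3 values shown sit. Compound 3 therefore stands where every value shown stands, at the limit, with no measured number to rank it against.

Compound 4, `C=C1C[C@]23C[C@@]1(O)CC[C@@H]2c1cccc(C)c1[C@@H]3Cn1cc(-c2ccccn2)nn1`, differs from compound 3 by pyridin-2-yl in place of phenyl on an aromatic carbon. Going by the values given here, no measured step touches this exchange of pyridin-2-yl for phenyl, so there is nothing to set an expected direction or size beyond the scatter. Since compound 3 gives only a limit, compound 4 is expected to sit near that limit as well, with an estimated 30000 nM in this assay, ranging from 8000 nM to 100000 nM. The expected step that the limit leaves unreadable from compound 3 to compound 4 is accordingly none beyond the scatter.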

Compound 4, half-maximal inhibitory concentration: > 20000 nM
Compound 4: no number, only a limit; the forecaster's own chance of this, stated with the estimate: 80%; the middle value lies beyond the limit too.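

No step can be read from compound 3 to compound 4, because each gives a limit of the assay rather than a number: the limit of > 20000 nM in this assay, at which 4 of the 4 values shown sit.

The compounds shown leave open how far apart they truly lie in this assay, and whether any change on the shared core would give a readable number.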